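Chain lengthening in a series of urea analogues

The source may hold more compounds than are shown below. What is called first, only, known or untested is meant among the compounds shown, and "the series" means these compounds.

Three ureas have been examined in an ADME assay on the whole organism with Oryza sativa as the target, tested at 0.1 uM; on this read-out lower numbers stand for a stronger effect and higher numbers for a weaker effect at the one concentration tested. Compound 1 `Cc1ccccc1NC(=O)N[C@H](C)c1ccccc1` gives 100%, and compound 2 `CCc1ccccc1NC(=O)N[C@H](C)c1ccccc1` gives 101%. The step of a number 1 percentage points higher from compound 1 to compound 2 (within the scatter) arises from the change (methyl in place of hydrogen on a saturated chain carbon bound to an aromatic carbon). Compound 3 `CCCCCc1ccc(NC(=O)N[C@H](C)c2ccccc2)cc1` gives 100%, which stands level with compound 1 at the digits reported; the difference between the cores of compound 1 and compound 3 is not broken down here.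

Compound 4 `CCCCCCc1ccc(NC(=O)N[C@H](C)c2ccccc2)cc1` has not yet been measured. It differs from compound 3 by methyl in place of hydrogen on a saturated chain carbon, five bonds along the chain from an aromatic carbon. This is the same kind of change as that from compound 1 to compound 2, though the place differs: in the earlier pair the saturated chain carbon is bound to an aromatic carbon, whereas here it lies five bonds along the chain from an aromatic carbon. Because the earlier step of a number 1 percentage points higher from compound 1 to compound 2 (within the scatter) stayed within the scatter, and because compound 3 itself gives 100%, the expected step is no change at the digits printed from compound 3 to compound 4 (within the scatter). Compound 4 is therefore estimated at 100%, with a range from 92% to 108%.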

Compound 4, a percentage reported as activity, at one concentration (the size of the read-out at that concentration, not a potency): 100%
Compound 4: middle estimate and measured number agree at the digits printed; the range from low to high includes it.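

In this assay the added methyl gives no change at the digits printed from compound 3 to compound 4 (within the scatter), and set beside the earlier step, the same change reads alike on the two cores: the same change on two cores in this assay, a number 1 percentage points higher (within the scatter) from compound 1 to compound 2 and no change at the digits printed (within the scatter) from compound 3 to compound 4, 1 percentage points apart, within the scatter of two such steps. Within these two pairs, then, the change carries from one core to the other with no step beyond the scatter. Since neither step shows a measurable effect at the one concentration tested, this is agreement between two flat results; it does not show that the change would behave alike on a further core or on a core where the read-out moves.

The compounds shown leave open whether a longer chain than that of compound 4, or a chain ending in an amine or a carboxylic acid, would shift the read-out in this assay at all. They also leave open whether any member of this series reaches a lower number, and how these compounds would read at other concentrations.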